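Nitro for methyl on the benzoxazolone-type core of compound 3

The compounds below may be only part of what the source reports. "The series", "measured", "known", "first", "only" and "open" are said of these compounds alone.

Within the data shown here, compound 3 `Cc1ccc2c(c1)oc(=O)n2C(=O)NCCCCc1ccccc1` stands second highest of the three numbers measured so far in an assay on HEK293 cells for inhibition of acid ceramidase (Homo sapiens), with a stated time of 10 min (a higher number here means a weaker inhibitor, a lower number a stronger inhibitor), where compound 3 gives 66 nM. Its nearest neighbour is compound 1 `COc1ccc(-c2ccc3c(c2)oc(=O)n3C(=O)NCCCCc2ccccc2)cc1`, which in this assay gives 67 nM; the pair sits within the scatter, a 1.0-fold lower number from compound 1 to compound 3 (0.01 log units; within the scatter). The furthest is compound 2 `O=C(c1ccc(Cl)cc1)c1ccc2c(c1)oc(=O)n2C(=O)NCCCCc1ccccc1`, which in this assay gives 14 nM; the step of a 4.7-fold higher number from compound 2 to compound 3 (0.67 log units; beyond the scatter) is beyond the scatter, as is a 4.8-fold lower number from compound 1 to compound 2 (0.68 log units; beyond the scatter).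

Compound 4 `O=C(NCCCCc1ccccc1)n1c(=O)oc2cc([N+](=O)[O-])ccc21` differs from compound 3 by nitro in place of methyl on an aromatic carbon. Among the measured compounds shown here, no measured step involves nitro; the two steps that touch the same position show that methyl and 4-methoxyphenyl are interchangeable within the scatter, while the (4-chlorophenyl)carbonyl group gives a modestly lower number. A small substituent bearing two acceptors is thus only loosely bracketed by these steps, and a modest lowering or none beyond the scatter is expected, a 1.9-fold lower number from compound 3 to compound 4 (0.28 log units; within the scatter). For compound 4 the estimate in this assay is 35 nM, with a range of 12 nM to 100 nM.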

Compound 4, half-maximal inhibitory concentration: 3 nM
For compound 4 the middle estimate is 12-fold (1.07 log units) above the measured one; measured number outside the range, below it.
By their numbers in this assay, from the lowest: compound 4; then compound 2; then compounds 3 and 1 (each within the scatter of the next).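

Nitro in place of methyl on this aromatic carbon gives a 22-fold lower number from compound 3 to compound 4 (1.34 log units; beyond the scatter) in this assay, and nitro in place of 4-methoxyphenyl gives a 22-fold lower number from compound 1 to compound 4 (1.35 log units; beyond the scatter), so the position responds far more strongly than the within-scatter match of methyl and 4-methoxyphenyl had shown. Nitro also goes beyond the (4-chlorophenyl)carbonyl group, with a 4.7-fold lower number from compound 2 to compound 4 (0.67 log units; beyond the scatter), and that group no longer gives the lowest number at this position. Nothing measured here accounts for these gains.

From the compounds shown here alone, it remains open whether the gain is particular to nitro or would also appear with a nitrile, a trifluoromethyl or an amine on the same carbon. Going by these compounds, it is equally open whether the gain would persist with a shorter chain on the amide nitrogen.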